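Swapping a cyclohexyl for a benzoylmethyl group

A few compounds are considered here, and "the series" means these few. Any claim that something is new, unique, unknown or untested is made for them only; others in the source may bear on it.

Three compounds share one core and differ only at the amine nitrogen in a ring. Compound 1 `c1ccc(OCc2nc3c(OCCCN4CCCCC4)cccc3n2CCCC2CCN(CCC3CCCCC3)CC2)cc1` gives 0.285 nM in an in vitro assay on AV12 cells for binding affinity to Neuropeptide Y receptor type 1 (Homo sapiens); a lower number here means a stronger inhibitor, a higher number a weaker inhibitor; compound 2 `c1ccc(OCc2nc3c(OCCCN4CCCCC4)cccc3n2CCCC2CCNCC2)cc1`, which carries hydrogen there, gives 4.5 nM; compound 3 `c1ccc(OCc2nc3c(OCCCN4CCCCC4)cccc3n2CCCC2CCN(CC3CCCCC3)CC2)cc1` gives 0.393 nM. Compound 3 thus stands second of the three numbers, close to compound 1 and far from compound 2: the pair of steps a 16-fold higher number from compound 1 to compound 2 (1.20 log units; beyond the scatter) and an 11-fold lower number from compound 2 to compound 3 (1.06 log units; beyond the scatter) are both large, while a 1.4-fold higher number from compound 1 to compound 3 (0.14 log units; within the scatter) stays within the scatter.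

Compound 4 `O=C(CCN1CCC(CCCn2c(COc3ccccc3)nc3c(OCCCN4CCCCC4)cccc32)CC1)c1ccccc1` is unmeasured; it differs from compound 3 by benzoylmethyl in place of cyclohexyl on a saturated chain carbon bound to an amine nitrogen in a ring. Among the measured compounds shown here, the closest precedent is the within-scatter step from compound 1 to compound 3, which shows that varying the ring-bearing substituent on the chain hardly moves the number, whereas only removing it altogether, as in compound 2, costs a large step. Compound 4 is therefore expected to give 0.7 nM, within 0.2 nM to 3 nM, an expected step of a 1.8-fold higher number from compound 3 to compound 4 (0.25 log units; within the scatter).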

Compound 4, inhibition constant: 0.112 nM
Estimate against measurement, compound 4: 6.3-fold (0.80 log units) above; measured number outside the range, below it.
By their numbers in this assay, from the lowest: compound 4; then compounds 1 and 3 (each within the scatter of the next); then compound 2.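

In this assay this position proves sensitive to which ring-bearing substituent sits on the amine nitrogen, which the earlier within-scatter step did not show: 2-benzoylethyl gives a 3.5-fold lower number from compound 3 to compound 4 (0.55 log units; beyond the scatter) and also a 2.5-fold lower number from compound 1 to compound 4 (0.41 log units; beyond the scatter) and so stands apart from both cyclohexyl-bearing groups. The gain over the free amine widens as well, to a 40-fold lower number from compound 2 to compound 4 (1.60 log units; beyond the scatter) and so compound 4 has the lowest number of the four. The change brings in an aromatic ring and a carbonyl together, so these compounds cannot separate the share of each, and nothing available here accounts for the step.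

Left open is whether a plain 2-phenylethyl group or an alcohol in place of the carbonyl would hold the number of compound 4. Also open, as far as these compounds go, is how a fluorine or a methoxy group on the benzoyl ring would move it.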